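A Difluoromethoxy Step Carried Over to a Second Core

This account rests on a few compounds, and the source may have more. Where it says the series, first, only, none or still open, it means among the compounds named here.

Compound 2 `COCCCOc1ccnc(COc2ccc(CS(=O)(=O)c3nc4ccccc4[nH]3)cc2OC)c1C` and compound 1 `COCCCOc1ccnc(COc2ccc(CS(=O)(=O)c3nc4cc(OC(F)F)ccc4[nH]3)cc2OC)c1C` share a core and differ in one place. In a functional assay on cells (Erythrocyte, Homo sapiens) (on this read-out lower numbers stand for stronger inhibition and higher numbers for weaker inhibition), compound 2 gives 355 nM, and compound 1 gives 142 nM. The change between them is difluoromethoxy in place of hydrogen on an aromatic carbon, and it made a 2.5-fold lower number from compound 2 to compound 1 (0.40 log units; beyond the scatter).

Compound 3 `COc1cc(CS(=O)(=O)c2nc3ccccc3[nH]2)ccc1OCc1nccc(OC)c1OC` is built on a different core; how that core differs from the core of compound 2 is not broken down here. In this assay compound 3 gives 212 nM. Its value and those of compound 1 and compound 2 lie within the usual scatter of one another, so no order among the three is drawn.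

Compound 4 `COc1cc(CS(=O)(=O)c2nc3cc(OC(F)F)ccc3[nH]2)ccc1OCc1nccc(OC)c1OC` has not yet been measured. It carries the same change relative to compound 3 that compound 1 carries relative to compound 2: difluoromethoxy in place of hydrogen on an aromatic carbon. For the measured compounds named here, the change sits at the same place in both pairs, so the single earlier step is the only guide. Because the earlier step gave a 2.5-fold lower number from compound 2 to compound 1 (0.40 log units; beyond the scatter), compound 4 is expected to show a 2.5-fold lower number from compound 3 to compound 4 (0.40 log units; beyond the scatter) in this assay. This rests on one example on a different core, so the expectation is held loosely. Compound 4 is therefore estimated to give 85 nM, with the result expected to fall between 40 nM and 180 nM.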

Compound 4, half-maximal inhibitory concentration: 186 nM
For compound 4 the middle estimate is 2.2-fold (0.34 log units) below the measured one; measured number outside the range, above it.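

In this assay, for the compounds shown here, putting difluoromethoxy in place of hydrogen on the core of compound 3 gave a 1.1-fold lower number from compound 3 to compound 4 (0.06 log units; within the scatter), so on this core the change leaves no step that can be told apart from the scatter. Set beside the step on the first core, this result does not show that the two cores respond differently: the same change on two cores in this assay, a 2.5-fold lower number (0.40 log units; beyond the scatter) from compound 2 to compound 1 and a 1.1-fold lower number (0.06 log units; within the scatter) from compound 3 to compound 4, 2.2-fold (0.34 log units) apart, within the scatter of two such steps. The two pairs are therefore compatible with a step of similar size on both cores, and equally with a real step on the first core and none on the second; with a single pair on each core, they neither establish that the change carries over nor show that it fails to.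

Among the compounds shown, only hydrogen and difluoromethoxy stand at this aromatic carbon, so it remains open whether the step on either core is particular to difluoromethoxy or would also appear with a smaller or larger group there, such as a chlorine, a nitrile, a trifluoromethoxy or an amine. From the compounds shown here alone, it also remains open whether further pairs on these two cores, each differing only in such a group, would bring the steps on the two cores together or draw them apart.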